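A few compounds are considered here, and "the series" means these few. Any claim that something is new, unique, unknown or untested is made for them only; others in the source may bear on it.

Compound 1 `COc1ccc(C2CC(c3ccc4ccccc4c3)=NN2C2=NC(=O)/C(=C3\C(=O)Nc4ccccc43)S2)cc1` and compound 2 `COc1ccc(C2CC(c3ccc4ccccc4c3)=NN2C2=NC(=O)/C(=C3\C(=O)Nc4ccc(Br)cc43)S2)cc1` share one core and differ in a single place: bromo in place of hydrogen on an aromatic carbon. In a functional assay on cells (Melanoma cell, Homo sapiens) for cytotoxicity, read by sulforhodamine B assay, with a stated time of 48 h (a lower number here means a stronger inhibitor of growth, a higher number a weaker inhibitor of growth), compound 1 gives 4800 nM, while compound 2 gives 69 nM, so the step is a 70-fold lower number from compound 1 to compound 2 (1.84 log units; beyond the scatter). Compound 3 `CN(C)c1ccc(C2CC(c3ccccc3)=NN2C2=NC(=O)/C(=C3\C(=O)Nc4ccccc43)S2)cc1` rests on a different core; the difference between the core of compound 1 and the core of compound 3 is not broken down here. In this assay compound 3 gives 6900 nM, a value that lies within the scatter of compound 1 and far above compound 2, which is the strongest inhibitor of growth among the three measured compounds, its steps to both others lying beyond the scatter.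

Compound 4 `CN(C)c1ccc(C2CC(c3ccccc3)=NN2C2=NC(=O)/C(=C3\C(=O)Nc4ccc(Br)cc43)S2)cc1` is the still unmeasured partner of compound 3. It differs from compound 3 by bromo in place of hydrogen on an aromatic carbon, and this is the same change as that from compound 1 to compound 2, made at the same kind of place. Within the data shown here, whether the step carries over from one core to the other is the open question, since only one example of the change has been measured. The expectation for the step in this assay is a 46-fold lower number from compound 3 to compound 4 (1.66 log units; beyond the scatter), somewhat tempered relative to the measured pair because the size of a 70-fold lower number from compound 1 to compound 2 (1.84 log units; beyond the scatter) comes from a single example on a different core. Compound 4 is therefore estimated at 150 nM in this assay, with a likely range from 40 nM to 700 nM.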

Compound 4, concentration for 50% growth inhibition: 200 nM
Estimate against measurement, compound 4: 1.3-fold (0.12 log units) below, within the range that was stated.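

On the core of compound 3, bromo in place of hydrogen on an aromatic carbon again brings a large change in this assay, with a 35-fold lower number from compound 3 to compound 4 (1.54 log units; beyond the scatter) as the new step. The change therefore carries from one core to the other in this series, in direction and, within the scatter, in size, and the two steps can be read as one effect on growth inhibition across these two pairs: the same change on two cores in this assay, a 70-fold lower number (1.84 log units; beyond the scatter) from compound 1 to compound 2 and a 35-fold lower number (1.54 log units; beyond the scatter) from compound 3 to compound 4, 2.0-fold (0.30 log units) apart, within the scatter of two such steps. This shows transfer only between the two cores seen here and for one group at one kind of place, and it does not show that the step would hold on any further core, nor does it say why the bromo compounds are the stronger inhibitors of growth in each pair.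

The compounds shown leave open whether chloro, fluoro, methoxy or a nitrile at the same place would lower the number as bromo does, or whether the effect is particular to bromo. They also leave open whether bromo on another carbon of that six-membered aromatic ring would give a step of similar size, and whether an amine or a carboxylic acid there would keep or lose it.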